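Inverting Both Stereocentres of Compound 3

This account rests on a few compounds, and the source may have more. Where it says the series, first, only, none or still open, it means among the compounds named here.

In an ADME assay on S9 fraction from liver (Rattus norvegicus) for metabolic stability, with a stated time of 1 h (a lower number here means that less of the compound is left, a higher number that more of the compound is left), compound 1 (`N#Cc1cnc(NCc2ccccc2C(F)(F)F)cc1N[C@H]1CC[C@@H](O)CC1`) gives 31% and compound 2 (`N#Cc1cnc(NCc2cnccc2C(F)(F)F)cc1N[C@H]1CC[C@H](O)CC1`) gives 25% as a value within the scatter of the first. Compound 3 (`N#Cc1cnc(NCc2ccccc2C(F)(F)F)cc1N[C@H]1C[C@@H](C(N)=O)C1`) stands highest of the three with 83% and lies beyond the scatter of both. Compound 4 (`N#Cc1cnc(NCc2ccccc2C(F)(F)F)cc1N[C@H]1C[C@H](C(N)=O)C1`) differs from compound 3 only in configuration as drawn (the two compounds have the same atoms and bonds and differ only in configuration as drawn: 2 of 2 stereo elements differ (all stereocentres are inverted: mirror images); a stereocentre at a saturated ring carbon is drawn s in compound 3 and r in compound 4; a stereocentre at a saturated ring carbon is drawn s in compound 3 and r in compound 4) and has the same atoms and bonds.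

Among the measured compounds shown here, the only measured step that bears on this is a number 52 percentage points higher from compound 1 to compound 3 (beyond the scatter) and it is large, with 3-carbamoylcyclobutyl in place of 4-hydroxycyclohexyl. That step exchanges the group itself, whereas compound 4 keeps it. For the measured compounds named here, no measured pair differs in configuration alone, so the size of such a change remains unknown. No step beyond the scatter is therefore expected in this assay for this change, although the uncertainty is wide. The estimate means a number 7 percentage points lower from compound 3 to compound 4 (within the scatter) as the expected step. Compound 4 is estimated at 76% with 55% to 92% as its expected range.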

Compound 4, percent of the compound remaining: 54%
Compound 4: middle estimate off by 22 percentage points, on the high side; measured number outside the range, below it.
By their numbers in this assay, from the lowest: compounds 2 and 1 (each within the scatter of the next); then compound 4; then compound 3.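

In this assay, among the compounds shown here, the earlier compounds could not show whether the configuration of the 3-carbamoylcyclobutyl group matters, and the new result gives a number 29 percentage points lower from compound 3 to compound 4 (beyond the scatter). The exchange of 4-hydroxycyclohexyl for this group therefore has no single size: it gives a number 23 percentage points higher from compound 1 to compound 4 (beyond the scatter), still beyond the scatter, against a number 52 percentage points higher from compound 1 to compound 3 (beyond the scatter) with the other configuration. The two cyclobutyl compounds part because of configuration alone: the fact that compounds 3 and 4 differ only in the configuration as drawn

Left open is how a carboxylic acid in place of the carbamoyl group on the cyclobutyl ring would fare in either configuration. Going by these compounds, it also remains open whether configuration counts as much on the 4-hydroxycyclohexyl group, since compound 1 and compound 2 differ in more than one place.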